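This account rests on a few compounds, and the source may have more. Where it says the series, first, only, none or still open, it means among the compounds named here.

Measured so far: compound 1 `N#Cc1cnc(NCc2cnccc2C(F)(F)F)cc1NC[C@H]1CC[C@H](O)CC1` gives 2000 nM; compound 2 `N#Cc1cnc(NCc2cnccc2C(F)(F)F)cc1NCC1CCOCC1` gives 5000 nM.

In an assay on isolated protein for inhibition of protein kinase C delta type (Homo sapiens), read by TR-FRET, with a stated time of 2 h (on this read-out lower numbers stand for stronger inhibition and higher numbers for weaker inhibition), compound 2 stands at the higher, weaker of the two numbers, compound 1 being the nearer and stronger. The step to compound 3 `CC1(C)C[C@@H](Nc2cc(NCc3cnccc3C(F)(F)F)ncc2C#N)CC[C@@H]1O` is 4-hydroxy-3,3-dimethylcyclohexyl in place of (oxan-4-yl)methyl on a nitrogen on an aromatic ring. Among the compounds with values here, only one measured step bears on it: a 2.5-fold higher number from compound 1 to compound 2 (0.40 log units; beyond the scatter), which covers the swap of ring oxygen for a hydroxyl but not the removal of the linking carbon or the added dimethyl. Compound 3 is therefore expected to move back toward compound 1, a step of a 3.3-fold lower number from compound 2 to compound 3 (0.52 log units; beyond the scatter), giving an estimated 1500 nM within 300 nM to 8000 nM.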

Compound 3, half-maximal inhibitory concentration: 2400 nM
Estimate against measurement, compound 3: 1.6-fold (0.20 log units) below; measured number inside the range.
By their numbers in this assay, from the lowest: compounds 1 and 3 (each within the scatter of the next); then compound 2.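

In this assay, 4-hydroxy-3,3-dimethylcyclohexyl on the nitrogen reads stronger than (oxan-4-yl)methyl (a 2.1-fold lower number from compound 2 to compound 3 (0.32 log units; beyond the scatter)), yet it cannot be told apart from (4-hydroxycyclohexyl)methyl (a 1.2-fold higher number from compound 1 to compound 3 (0.08 log units; within the scatter)). This position therefore accepts a ring attached directly to the nitrogen, with no chain carbon in between, when that ring also carries the hydroxyl and two methyl groups. Nothing available explains either step. Still open, on these data alone, is how each of these changes acts alone, and whether an amine in place of the hydroxyl would give a similar number.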